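Moving a hydroxyl around the phenyl ring of a prenylated chalcone

The compounds below may be only part of what the source reports. "The series", "measured", "known", "first", "only" and "open" are said of these compounds alone.

Measured compounds:
compound 1 `COc1ccc(/C=C/C(=O)c2c(OC)cc(O)c(CC=C(C)C)c2O)cc1OC`: 17100 nM
compound 2 `COc1cc(O)c(C(=O)/C=C/c2ccc(O)cc2)c(OC)c1CC=C(C)C`: 25600 nM
compound 3 `COc1cc(O)c(CC=C(C)C)c(O)c1C(=O)/C=C/c1ccccc1O`: 5900 nM

In a functional assay on HeLa cells (Homo sapiens) for cytotoxicity, read by MTT assay (on this read-out lower numbers stand for stronger inhibition and higher numbers for weaker inhibition), compound 3 gives 5900 nM, the lowest of the three numbers: compound 1 lies beyond the scatter above it, and compound 2 further still. Compound 4 `COc1cc(O)c(CC=C(C)C)c(O)c1C(=O)/C=C/c1cccc(O)c1` keeps the core of compound 3 and differs only in the ring on the chain: 3-hydroxyphenyl in place of 2-hydroxyphenyl on a double-bonded chain carbon bound to a double-bonded chain carbon. Going by the values given here, no measured pair shows this kind of move of a hydroxyl, so the size of the step is uncertain. Compound 2, carrying a ring with its hydroxyl in yet another position on a different core, gives a weaker number, which leaves the direction open. The estimated step of a 1.5-fold higher number from compound 3 to compound 4 (0.18 log units; within the scatter) is expected to be small, likely within the scatter or a modest weakening. Compound 4 is therefore estimated at 9000 nM, with a range from 3500 nM to 25000 nM.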

Compound 4, half-maximal inhibitory concentration: 4800 nM
Estimate against measurement, compound 4: 1.9-fold (0.27 log units) above; measured number inside the range.
By their numbers in this assay, from the lowest: compounds 4 and 3 (each within the scatter of the next); then compounds 1 and 2 (each within the scatter of the next).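

In this assay, putting the hydroxyl on the other ring carbon gives a 1.2-fold lower number from compound 3 to compound 4 (0.09 log units; within the scatter) on an unchanged core. Going by these compounds alone, this is the first pair that isolates this move, and it shows that 3-hydroxyphenyl and 2-hydroxyphenyl cannot be told apart at this place on the chain. No evidence at hand bears on why the two numbers agree.

As far as these compounds go, whether this place needs a hydroxyl at all remains open. So does how an amine or a carboxylic acid in its stead would behave on this core.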